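This account rests on a few compounds, and the source may have more. Where it says the series, first, only, none or still open, it means among the compounds named here.

Of the compounds shown here, two built on the same core have been measured in a functional assay on FM3A cells (Mus musculus) for inhibition; on this read-out higher numbers stand for weaker inhibition and lower numbers for stronger inhibition. Compound 1 `C/C(=C\COc1c(Cl)cccc1Cl)CC/C=C(\C)C1CC(=O)C(C)(C)O1` gives 51.2 ug/mL. Compound 2 `C/C(=C\COc1ccc2ccccc2c1)CC/C=C(\C)C1CC(=O)C(C)(C)O1` gives 38.4 ug/mL, the lowest of the two numbers; its nearest neighbour is compound 1, and the gap between the two lies within the usual scatter, so they cannot be told apart on these data. Compound 3 `C/C(=C\COc1ccc2ccccc2c1)CC/C=C(\C)C1=CC(=O)C(C)(C)O1` has not yet been measured. It differs from compound 2 in one place: a group of 8 heavy atoms (6 carbon, 2 oxygen; one five-membered non-aromatic ring with 1 hetero atom) in place of a group of 8 heavy atoms (6 carbon, 2 oxygen; one five-membered non-aromatic ring with 1 hetero atom), on a double-bonded chain carbon bound to a double-bonded chain carbon and a saturated chain carbon. Among the measured compounds shown here, no measured pair shows what this change does, so the numbers at hand point neither up nor down. Compound 3 is expected to give about 35 ug/mL in this assay, with a range from 12 ug/mL to 100 ug/mL. This estimate means a step of a 1.1-fold lower number from compound 2 to compound 3 (0.04 log units; within the scatter) that is expected to stay within the scatter, neither clearly stronger nor clearly weaker.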

Compound 3, half-maximal inhibitory concentration: 56.4 ug/mL
Estimate against measurement, compound 3: 1.6-fold (0.21 log units) below; measured number inside the range.
By their numbers in this assay, from the lowest: compounds 2, 1 and 3 (each within the scatter of the next).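

In this assay, among the compounds shown here, the swap of the 5,5-dimethyl-4-oxooxolan-2-yl group for its counterpart with 2 double bonds outside aromatic rings gives a 1.5-fold higher number from compound 2 to compound 3 (0.17 log units; within the scatter), the first reading of any change at this place. On a double-bonded chain carbon bound to a double-bonded chain carbon and a saturated chain carbon, this added double bond therefore leaves the read-out inside the scatter, and the two ring forms cannot be told apart on these data. Nothing at hand offers a reason for this result. From the compounds shown here alone, whether the same swap behaves alike on the core of compound 1 stays open, as only compound 2 and compound 3 speak to it. Also open, going by these compounds, is what a larger change here would do, such as an amine or a carboxylic acid in place of the ring.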